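Methoxy for trifluoromethyl on the carbonyl carbon

The source may hold more compounds than are shown below. What is called first, only, known or untested is meant among the compounds shown, and "the series" means these compounds.

The series shares one core with a sulfonyl or carbonyl group on the ring nitrogen. Compound 1 `CCCS(=O)(=O)Nc1cccc2c1CCCC2c1c[nH]cn1` carries a propylsulfonyl group. In an assay on isolated protein for binding affinity to Alpha-1D adrenergic receptor (Rattus norvegicus), read by radioligand binding (on this read-out higher numbers stand for weaker inhibition and lower numbers for stronger inhibition), compound 1 gives only a limit, < 10000 nM, not a number. Compound 2 `CN(C)S(=O)(=O)Nc1cccc2c1CCCC2c1c[nH]cn1` carries a dimethylsulfamoyl group and in this assay compound 2 gives 1580 nM. Compound 3 `O=C(Nc1cccc2c1CCCC2c1c[nH]cn1)C(F)(F)F` carries a (trifluoromethyl)carbonyl group and in this assay compound 3 gives 3310 nM, the highest of the two numbers shown. The step of a 2.1-fold higher number from compound 2 to compound 3 (0.32 log units; beyond the scatter) is modest and beyond the scatter. The steps a step that the limit leaves unreadable from compound 1 to compound 2 and a step that the limit leaves unreadable from compound 1 to compound 3 cannot be sized because of the limit of < 10000 nM in this assay, at which 1 of the 3 values shown sits.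

Compound 4 `COC(=O)Nc1cccc2c1CCCC2c1c[nH]cn1` differs from compound 3 by methoxy in place of trifluoromethyl on a carbonyl carbon. Among the measured compounds shown here, no measured step changes the substituent on the carbonyl carbon; the one readable step, from a sulfonyl group to a carbonyl group on the nitrogen, is modest. On that basis the change to compound 4 is expected to move the number by no more than a modest amount, in an unknown direction, so the expected step is a 1.1-fold higher number from compound 3 to compound 4 (0.02 log units; within the scatter). In this assay compound 4 is therefore estimated at 3500 nM, within 1000 nM to 10000 nM.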

Compound 4, inhibition constant: 3020 nM
Estimate against measurement, compound 4: 1.2-fold (0.06 log units) above; the range from low to high includes it.
By their numbers in this assay, from the lowest: compounds 2, 4 and 3 (each within the scatter of the next, the first and the last beyond it).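

Methoxy in place of trifluoromethyl is the first readable change on the carbonyl carbon itself, and in this assay there is a 1.1-fold lower number from compound 3 to compound 4 (0.04 log units; within the scatter) so this swap leaves the two compounds indistinguishable on this read-out. Among the compounds shown here, the comparison with the sulfamoyl group is less clear-cut than the earlier compounds suggested: a 2.1-fold higher number from compound 2 to compound 3 (0.32 log units; beyond the scatter) for the (trifluoromethyl)carbonyl group, whereas there is a 1.9-fold higher number from compound 2 to compound 4 (0.28 log units; within the scatter) for the methoxycarbonyl group, so compound 4 cannot be told apart from either compound 2 or compound 3, and a separation between sulfonyl-type and carbonyl-type groups on the nitrogen is not general across these compounds. Compound 1 stands only as a limit, not a number, and its step to compound 4 cannot be read, as is true of all its steps: the limit of < 10000 nM in this assay, at which 1 of the 4 values shown sits.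

Still open, as far as these compounds go, is whether a dimethylamino group or a longer chain such as ethoxy on the carbonyl carbon would give a number that stands apart from those of compound 3 and compound 4 in this assay on the same core. Also open, from the compounds shown here alone, is where the propylsulfonyl group of compound 1 truly falls against the other three, and whether a carboxylic acid or a cyclopropyl ring on the carbonyl carbon would move the number beyond the scatter.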